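Methoxy in place of hydrogen on compound 2

This account rests on a few compounds, and the source may have more. Where it says the series, first, only, none or still open, it means among the compounds named here.

Compound 2 (`COc1cc(CCc2ccccc2)cc(OC)c1O`) gives 1040 nM in a functional assay on MKN-45 cells (Homo sapiens) for antiproliferative activity, read by MTT assay, with a stated time of 72 h (a lower number here means a stronger inhibitor, a higher number a weaker inhibitor), the lower of the two true numbers in the series. Compound 1 (`COc1cc(CCc2ccncc2)cc(OC)c1O`) gives 3810 nM, and a 3.7-fold lower number from compound 1 to compound 2 (0.56 log units; beyond the scatter) is a modest step beyond the scatter. Compound 3 (`COc1cc(CCc2ccc(Cl)cc2)cc(OC)c1O`) reads > 25000 nM, which is a limit of the assay. The chloro step, an at least 24-fold higher number from compound 2 to compound 3 (1.38 log units; beyond the scatter), is large, and its size rests on (the limit of > 25000 nM in this assay, at which 1 of the 3 values shown sits).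

Compound 4 (`COc1ccccc1CCc1cc(OC)c(O)c(OC)c1`) has methoxy in place of hydrogen on an aromatic carbon, ortho to a large group: methoxy in place of hydrogen on an aromatic carbon. Among the measured compounds shown here, the closest precedent is an at least 24-fold higher number from compound 2 to compound 3 (1.38 log units; beyond the scatter), the only measured substitution on this ring, and it points to a higher number in this assay. Chloro is a different group, and one example sets no rule, so a smaller rise is expected. The expected step is a 2.9-fold higher number from compound 2 to compound 4 (0.46 log units; beyond the scatter). For compound 4 the estimated value is 3000 nM, with an expected range of 700 nM to 20000 nM.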

Compound 4, half-maximal inhibitory concentration: 2480 nM
Estimate against measurement, compound 4: 1.2-fold (0.08 log units) above; low and high end bracket the measured number.
By their numbers in this assay, from the lowest: compound 2; then compounds 4 and 1 (each within the scatter of the next). At a limit, above all of these: compound 3.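

Placing a methoxy group on an aromatic carbon, ortho to a large group, gives a 2.4-fold higher number from compound 2 to compound 4 (0.38 log units; beyond the scatter) in this assay. Among the compounds shown here, this is the first substitution on this ring with a true number at both ends of the step, and the modest size shows that this change keeps the compound within the measurable range. Both substitutions shown on this ring raise the number, with no compound shown going against that, but the chloro step has no upper end: the limit of > 25000 nM in this assay, at which 1 of the 4 values shown sits.

With a single group at this place, the compounds shown do not separate the effect of methoxy from the effect of substituting this place at all. On these data alone, how fluoro, an amine or a carboxylic acid would read here stays open, as does a longer chain in place of the saturated one.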